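A few compounds are considered here, and "the series" means these few. Any claim that something is new, unique, unknown or untested is made for them only; others in the source may bear on it.

Compound 1 `COc1cccc(CNCCCNc2ccnc3cc(-c4ccccc4)ccc23)c1O` and compound 2 `COc1cccc(CNCCCNc2ccnc3cc(Cc4ccc(F)cc4)ccc23)c1O` share one core and differ only in the group carried on a single aromatic carbon. In a physicochemical assay for acid dissociation, compound 1 gives 9.47, and compound 2 gives 9.47. The step of no change at the digits printed from compound 1 to compound 2 (within the scatter) shows that exchanging the group at that carbon left the acid dissociation constant unchanged within the scatter, so compound 2 stands level with compound 1 on the numbers at hand. Compound 3 `COc1ccc(-c2ccc3c(NCCCNCc4cccc(OC)c4O)ccnc3c2)cc1` is the next variation at the same place: 4-methoxyphenyl in place of 4-fluorobenzyl on an aromatic carbon. Within the data shown here, the only measured step that bears on this, from compound 1 to compound 2, also exchanged the group on this aromatic carbon and produced no change beyond the scatter. Compound 3 is therefore expected to give 9.47 in this assay, within 9.2 to 9.8. The expected step of no change at the digits printed from compound 2 to compound 3 (within the scatter) is none beyond the scatter.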

Compound 3, acid dissociation constant: 9.47
Estimate against measurement, compound 3: no gap at the digits printed, within the range that was stated.
By their numbers in this assay, from the lowest: compounds 1, 2 and 3 (each within the scatter of the next).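

Exchanging 4-fluorobenzyl for 4-methoxyphenyl at this aromatic carbon in this assay gives no change at the digits printed from compound 2 to compound 3 (within the scatter) and so adds a second exchange at this place that leaves the read-out level. The entering group counts one hydrogen-bond acceptor where the leaving group counts none, and methoxy in place of hydrogen on an aromatic carbon likewise gives no change at the digits printed from compound 1 to compound 3 (within the scatter) as its result. Nothing among the available findings explains why the read-out stays level across these groups.

All three groups shown carry a six-membered aromatic ring of carbon only, so these compounds cannot say how a group without that ring, such as a longer chain, would read at this place. As far as these compounds go, whether an amine or a carboxylic acid on this aromatic carbon would shift this assay also remains open.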